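Lengthening the propyl chain of compound 2 to butyl

The source may hold more compounds than are shown below. What is called first, only, known or untested is meant among the compounds shown, and "the series" means these compounds.

compound 1 `CCOC(=O)c1cnc(-c2ccccc2N)[nH]c1=O`: "not determined" (no result reported)
compound 2 `CCCOc1ccccc1-c1ncc(C(=O)OCC)c(=O)[nH]1`: 5 mg/kg

Among the measured compounds shown here, in a functional assay on the whole organism (strain Sprague-Dawley) for inhibition, with Rattus norvegicus as the target, with a stated time of 10 min (a higher number here means that more compound is needed for the effect, a lower number that less compound is needed), compound 2 gives 5 mg/kg as the only number available, since compound 1 has no result. Compound 3 `CCCCOc1ccccc1-c1ncc(C(=O)OCC)c(=O)[nH]1` carries butyl where compound 2 carries propyl, with methyl in place of hydrogen on a saturated chain carbon (methyl in place of hydrogen on a saturated chain carbon, three bonds along the chain from an oxygen on an aromatic ring). For the measured compounds named here, no measured step shows what such a change does, so the expected move a 1.2-fold higher number from compound 2 to compound 3 (0.08 log units; within the scatter) is estimated to stay within the usual scatter, with no firm direction. In this assay compound 3 is estimated at 6 mg/kg with an expected range from 2 mg/kg to 20 mg/kg as the likely span.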

Compound 3, dose for 50% inhibition: 0.5 mg/kg
Compound 3: middle estimate off by 12-fold (1.08 log units), on the high side, and the stated range ends above it.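

In this assay, propyl to butyl gives a 10-fold lower number from compound 2 to compound 3 (1.00 log units; beyond the scatter) and so moves the number beyond the scatter. This shows that the chain is not indifferent to methyl in place of hydrogen at this place, three bonds along the chain from an oxygen on an aromatic ring, where one added carbon is enough to change the dose. Nothing shown here accounts for the size of this step. On these data alone, whether pentyl or a longer chain would lower the number further remains open, as does the effect of a branched chain such as isobutyl.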